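This account rests on a few compounds, and the source may have more. Where it says the series, first, only, none or still open, it means among the compounds named here.

Four compounds share a scaffold built around a five-membered sulfur- and nitrogen-containing ring. Compound 1 `COc1cccc(N2C(=O)CS/C2=N\c2csc(-c3ccccc3)c2)c1` is the simplest; in a functional assay on HT-29 cells (Homo sapiens) for cytotoxicity, read by MTT assay, with a stated time of 72 h (on this read-out higher numbers stand for weaker inhibition and lower numbers for stronger inhibition), compound 1 gives 38300 nM. Compound 2 `CN(C)c1ccc(/C=C2\S/C(=N\c3nc(-c4ccc(Cl)cc4)cs3)NC2=O)cc1` carries an extra benzylidene arm and a different substituted partner ring; in this assay compound 2 gives 500 nM. Compound 3 `Cc1ccc(/C=C2\S/C(=N\c3nc(-c4ccc(Cl)cc4)cs3)NC2=O)cc1` differs from compound 2 only in one group on the benzylidene ring, and in this assay compound 3 gives 500 nM. The step of no change at the digits printed from compound 2 to compound 3 (within the scatter) is within the scatter, so compounds 2 and 3 stand together at the low end, with compound 1 far higher.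

Compound 4 `COc1ccc(/C=C2\S/C(=N\c3nc(-c4ccc(Cl)cc4)cs3)NC2=O)cc1` is the next variation. The change is methoxy in place of methyl on an aromatic carbon. Going by the values given here, the only measured step at this position is the one from compound 2 to compound 3, and it shows no change; compound 1 bears a methoxy on a different ring and a different core, so it gives no direct guidance. The expected step of no change at the digits printed from compound 3 to compound 4 (within the scatter) is therefore small. Compound 4 is estimated at 500 nM, expected between 200 nM and 1500 nM.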

Compound 4, half-maximal inhibitory concentration: 400 nM
Compound 4: the middle estimate sits 1.3-fold (0.10 log units) above what was measured; measured number inside the range.
By their numbers in this assay, from the lowest: compounds 4, 2 and 3 (each within the scatter of the next); then compound 1.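

In this assay, the methoxy group can now be compared at this position with two different groups: methyl (a 1.3-fold lower number from compound 3 to compound 4 (0.10 log units; within the scatter)) and dimethylamino (a 1.3-fold lower number from compound 2 to compound 4 (0.10 log units; within the scatter)). Earlier, only methyl and dimethylamino could be compared here, so the result adds a third group, one that brings in an oxygen atom, and the read-out still does not separate it from either of the others. No measured information is available to explain why these three groups give values so close together.

Going by these compounds, the effect of a carboxylic acid, a primary amine or a longer chain such as butoxy at this position remains open. On these data alone, it is also open whether the same lack of separation would hold with the group elsewhere on the ring, or with the core of compound 1 in place of the shared core.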